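The source may hold more compounds than are shown below. What is called first, only, known or untested is meant among the compounds shown, and "the series" means these compounds.

Measured in an ADME assay on microsomes from liver (Homo sapiens) for metabolic stability, with a stated time of 30 min; a higher number here means that more of the compound is left, a lower number that less of the compound is left:

Compound 1 `CCCCc1nc(C)c(CC(=O)OC(C)C)c(=O)n1Cc1ccc(-c2ccccc2-c2noc(=O)[nH]2)cc1`: 17.5%
Compound 2 `CCCCOC(=O)Cc1c(C)nc(CCCC)n(Cc2ccc(-c3ccccc3-c3noc(=O)[nH]3)cc2)c1=O`: 2.8%
Compound 3 `CC#CCOC(=O)Cc1c(C)nc(CCCC)n(Cc2ccc(-c3ccccc3-c3noc(=O)[nH]3)cc2)c1=O`: 32%

Compound 1 stands second highest of the three numbers. The two measured steps that start from it run in opposite directions: a number 14.5 percentage points higher from compound 1 to compound 3 (beyond the scatter) and a number 14.7 percentage points lower from compound 1 to compound 2 (beyond the scatter). Between the other two, a number 29.2 percentage points higher from compound 2 to compound 3 (beyond the scatter). All three steps change only the chain on the oxygen of the ester; the rest of the shared core is the same in every measured compound.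

Compound 4 `CCCCc1nc(C2CC2)c(CC(=O)OC(C)C)c(=O)n1Cc1ccc(-c2ccccc2-c2noc(=O)[nH]2)cc1` is built from compound 1 by a change at a different place: cyclopropyl in place of methyl on an aromatic carbon. Among the compounds with values here, no measured step touches this aromatic carbon, so none of them bears directly on it; the measured steps show only that changes of a few carbon atoms elsewhere on this core shift this assay by modest amounts. For compound 4 the expectation is therefore a step of similar modest size, direction uncertain, a number 2.5 percentage points higher from compound 1 to compound 4 (within the scatter). The estimate for compound 4 in this assay is 20%, with a range from 6% to 45%.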

Compound 4, percent of the compound remaining: 9.9%
For compound 4 the middle estimate is 10.1 percentage points above the measured one, within the range that was stated.
By their numbers in this assay, from the lowest: compounds 2, 4 and 1 (each within the scatter of the next, the first and the last beyond it); then compound 3.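

In this assay, within the data shown here, the aromatic carbon next to the ring nitrogen is probed here for the first time, and cyclopropyl in place of methyl gives a number 7.6 percentage points lower from compound 1 to compound 4 (within the scatter). A group of 3 heavy atoms with a three-membered ring therefore replaces a single carbon at this position with no shift that can be told apart from the usual scatter. Among these compounds, the ester chain steps among the earlier compounds, by contrast, all lie beyond the scatter. Nothing available gives a reason for this result.

From the compounds shown here alone, it remains open how an ethyl group, a longer chain or an amine on this aromatic carbon would behave in this assay. Also open, going by these compounds, is whether cyclopropyl here would have a similarly small effect alongside the but-2-yn-1-yl ester of compound 3, which gives 32% with methyl at this position.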